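Solubility notes: from compound 1 to compound 3

This account rests on a few compounds, and the source may have more. Where it says the series, first, only, none or still open, it means among the compounds named here.

Measured so far:
- compound 1 `O=C1c2ccccc2CN1c1cnc(NCc2c(F)ccc3c2CCO3)n2cnnc12` — 4000 nM
- compound 2 `CC(=O)N1CCC(c2cnc(NCc3c(F)ccc4c3CCO4)c3cn[nH]c(=O)c23)CC1` — < 2000 nM (a limit, not a number)

In a physicochemical assay for solubility, read by LC-MS, in phosphate buffer, with a stated time of 24 h, at pH 7.4 (a higher number here means a more soluble compound, a lower number a less soluble compound), compound 1 gives 4000 nM. For compound 2 this assay returns only a limit, < 2000 nM, and that value sits at the limit of < 2000 nM in this assay, at which 1 of the 2 values shown sits. Within the data shown here, compound 1 therefore stands as the only real number in this assay; the one further value is a limit and gives no point of comparison. Among the measured compounds shown here, no pair of measured compounds differs in a single place, so no measured step is available to set the scale of what a single change can do here.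

Compound 3 `O=C1CC2(CC2)CN1c1cnc(NCc2c(F)ccc3c2CCO3)n2cnnc12` differs from compound 1 by a group of 8 heavy atoms (6 carbon, 1 nitrogen, 1 oxygen; one three-membered non-aromatic ring of carbon only, one five-membered non-aromatic ring with 1 hetero atom) in place of a group of 10 heavy atoms (8 carbon, 1 nitrogen, 1 oxygen; one five-membered non-aromatic ring with 1 hetero atom, one six-membered aromatic ring of carbon only), on an aromatic carbon. For the measured compounds named here, with no measured step to lean on, the expectation for this assay rests on the size and nature of the counted change alone. The step expected from compound 1 to compound 3 is a 2.5-fold higher number from compound 1 to compound 3 (0.40 log units; beyond the scatter), upward, and a little beyond the usual scatter rather than clearly outside it. Compound 3 is estimated at 10000 nM, with a range from 3000 nM to 40000 nM.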

Compound 3, solubility: 130000 nM
The estimate for compound 3 lay 13-fold (1.11 log units) below the measured number; the whole stated range lies below it.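

This position can move the read-out strongly in this assay: on an aromatic carbon, the group with the three-membered non-aromatic ring of carbon only, in place of the one with the six-membered aromatic ring of carbon only, gives a 33-fold higher number from compound 1 to compound 3 (1.51 log units; beyond the scatter), the first measured scale for a single change in this series. The step comes with the five-membered non-aromatic ring with 1 hetero atom, the 1 double bond outside aromatic rings, the 0 hydrogen-bond donors, the 1 hydrogen-bond acceptor and the absence of net charge all unchanged in the counts, so the counted differences are the ring carried and the heavy-atom total. No measured property shown bears on this step, which stands as a single pair with no stated cause.

One pair cannot separate the loss of the six-membered aromatic ring of carbon only from the gain of the three-membered non-aromatic ring of carbon only. Going by these compounds, whether a primary amine, a carboxylic acid or a plain ethyl chain on the same aromatic carbon would move the number in the same direction remains open, as does whether the step carries over to any other core.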